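The source may report more compounds than this note shows. Statements on the series, on what has been measured and on what is new or still open speak of the compounds shown alone.

Compound 1 `COc1ccccc1N1C(=O)C(C)SC1c1cccc(C(=O)NCCCCc2ccccc2)c1`: 2660 mL.min-1.g-1
Compound 2 `O=C(NCCCCc1ccccc1)c1cccc(C2SCC(=O)N2c2cccc(F)c2)c1`: 1840 mL.min-1.g-1
Compound 3 `Cc1ccnc(N2C(=O)CSC2c2cccc(C(=O)NCCCCn3cccn3)c2)c1`: 129 mL.min-1.g-1

These three compounds were measured in an ADME assay on microsomes from liver (Homo sapiens) for metabolic stability, read by LC-MS, using NADPH, with a stated time of 10 min, tested at 0.1 uM; a lower number here means slower removal, a higher number faster removal of the compound. Compound 2 gives 1840 mL.min-1.g-1, the second highest of the three numbers; its value and that of compound 1 lie within the usual scatter of each other, while the value of compound 3 lies well below, beyond the scatter. Compound 4 `O=C(NCCCCc1ccccc1)c1cccc(C2SCC(=O)N2c2ccccc2F)c1` has not yet been measured. It differs from compound 2 in one place: 2-fluorophenyl in place of 3-fluorophenyl on an amide-type nitrogen in a ring. The two groups hold the same atoms, joined differently. For the measured compounds named here, no measured pair shows what such a change does here, so no step beyond the scatter is expected in this assay. Compound 4 is therefore expected to give about 1600 mL.min-1.g-1, between 700 mL.min-1.g-1 and 3200 mL.min-1.g-1. The step of a 1.2-fold lower number from compound 2 to compound 4 (0.06 log units; within the scatter) that this estimate means is expected to stay within the usual scatter.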

Compound 4, intrinsic clearance in microsomes: 1710 mL.min-1.g-1
Compound 4: the middle estimate sits 1.1-fold (0.03 log units) below what was measured; measured number inside the range.
By their numbers in this assay, from the lowest: compound 3; then compounds 4, 2 and 1 (each within the scatter of the next).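

In this assay, 2-fluorophenyl in place of 3-fluorophenyl on the amide-type nitrogen gives a 1.1-fold lower number from compound 2 to compound 4 (0.03 log units; within the scatter), the first single-change pair available here. At this position, then, the two fluorophenyl groups cannot be told apart by intrinsic clearance in microsomes. No measured evidence bears on why they match.

Still open, going by these compounds, is whether a group of another kind on this phenyl ring, such as a carboxylic acid or an amine, would give a step beyond the scatter. Whether the same holds in other compounds with a different chain is also unknown.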